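The source may report more compounds than this note shows. Statements on the series, on what has been measured and on what is new or still open speak of the compounds shown alone.

Measured compounds in an assay on CHO cells for displacement of a labelled ligand from adenosine receptor A2b (Homo sapiens), read by scintillation counting, with a stated time of 75 min, in the presence of a further agent that is not named here; on this read-out higher numbers stand for weaker inhibition and lower numbers for stronger inhibition:
compound 1, `CCCn1c(=O)[nH]c2nc(-c3ccc(S(=O)(=O)N4CCN(Cc5ccc(Br)cc5)CC4)cc3)[nH]c2c1=O`, giving 0.153 nM;
compound 2, `CCCn1c(=O)[nH]c2nc(-c3ccc(S(=O)(=O)N4CCN(c5ccccc5Cl)CC4)cc3)[nH]c2c1=O`, giving 0.403 nM;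
compound 3, `CCCn1c(=O)[nH]c2nc(-c3ccc(S(=O)(=O)N4CCN(c5ccc(Cl)cc5F)CC4)cc3)[nH]c2c1=O`, giving 1.91 nM.

Compound 3 stands highest of the three numbers. Its nearest neighbour is compound 2, with a 4.7-fold higher number from compound 2 to compound 3 (0.68 log units; beyond the scatter), and its furthest is compound 1, with a 12-fold higher number from compound 1 to compound 3 (1.10 log units; beyond the scatter). Compound 4, `CCCn1c(=O)[nH]c2nc(-c3ccc(S(=O)(=O)N4CCN(Cc5cccc(C)c5)CC4)cc3)[nH]c2c1=O`, differs from compound 3 in a single place: 3-methylbenzyl in place of 4-chloro-2-fluorophenyl on an amine nitrogen in a ring.

Going by the values given here, two measured steps bear on this change. The step from compound 1 to compound 2 exchanged a benzyl group on the ring nitrogen for a directly attached phenyl ring, with a 2.6-fold higher number from compound 1 to compound 2 (0.42 log units; beyond the scatter), and the same exchange carried further gave a 12-fold higher number from compound 1 to compound 3 (1.10 log units; beyond the scatter). Compound 4 brings a benzyl group back onto that nitrogen, as in compound 1, so the number is expected to move the other way, and by a large margin: a 7.6-fold lower number from compound 3 to compound 4 (0.88 log units; beyond the scatter) is the step expected. Compound 4 is therefore estimated at 0.25 nM in this assay, within a range of 0.08 nM to 0.8 nM.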

Compound 4, inhibition constant: 0.397 nM
Beside the measured number, compound 4's estimate is 1.6-fold (0.20 log units) below it; the measured number falls inside the stated range.
By their numbers in this assay, from the lowest: compound 1; then compounds 4 and 2 (each within the scatter of the next); then compound 3.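

In this assay, a benzyl group on the ring nitrogen gives a low number without any halogen on its ring, with a 4.8-fold lower number from compound 3 to compound 4 (0.68 log units; beyond the scatter), yet the benzyl group alone does not settle the value, as the ring substituent still matters, with a 2.6-fold higher number from compound 1 to compound 4 (0.41 log units; beyond the scatter). The presence of the extra carbon does not decide the number by itself either: 3-methylbenzyl and the directly attached 2-chlorophenyl cannot be told apart, with a 1.0-fold lower number from compound 2 to compound 4 (0.01 log units; within the scatter). Nothing measured here offers a reason for these shifts.

Compounds 1 and 4 differ in both the substituent and where it sits on the ring, so the contribution of each remains unresolved. Also open, going by these compounds, is how an unsubstituted benzyl group or a longer phenethyl chain on this nitrogen would compare.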